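Extending the ethyl group of compound 3 to isopropyl

The source may report more compounds than this note shows. Statements on the series, on what has been measured and on what is new or still open speak of the compounds shown alone.

Measured so far in a functional assay on MCF7 cells (Homo sapiens) for cytotoxicity, read by MTT assay, with a stated time of 48 h (a higher number here means a weaker inhibitor of growth, a lower number a stronger inhibitor of growth), are three compounds
Compound 1 `COc1cc2ncn([C@@H]3O[C@H](CO)[C@@H](O)[C@H]3O)c2cc1OC` gives > 100000 nM as a limit of the assay
Compound 2 `Cn1c(C(F)(F)F)nc2cc(Cl)c(Cl)cc21` gives 39000 nM
Compound 3 `CCn1c(C(F)(F)F)nc2cc(Cl)c(Cl)cc21` gives 72900 nM

Compound 3 at 72900 nM sits within the scatter of compound 2 at 39000 nM and no order can be read between them. Compound 1 stands apart with a limit rather than a number.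

Compound 4 `CC(C)n1c(C(F)(F)F)nc2cc(Cl)c(Cl)cc21` follows from compound 3 by one change methyl in place of hydrogen on a saturated chain carbon bound to an aromatic nitrogen and a saturated chain carbon that turns ethyl to isopropyl. Going by the values given here, one measured step bears on it, methyl in place of hydrogen on a saturated chain carbon bound to an aromatic nitrogen, which gave a 1.9-fold higher number from compound 2 to compound 3 (0.27 log units; within the scatter) and so offers no size to carry forward. No step beyond the scatter is therefore expected in this assay for this change, in either direction. The expected step is a 1.0-fold higher number from compound 3 to compound 4 (0.01 log units; within the scatter) and it rests on that single comparison. A reading reported only as a limit remains possible for compound 4. Compound 4 is estimated at 75000 nM with an expected range from 33000 nM to 170000 nM for its value.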

Compound 4, concentration for 50% growth inhibition: 70500 nM
Estimate against measurement, compound 4: 1.1-fold (0.03 log units) above, within the range that was stated.
By their numbers in this assay, from the lowest: compounds 2, 4 and 3 (each within the scatter of the next). At a limit, above all of these: compound 1.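

In this assay, turning ethyl into isopropyl gave a 1.0-fold lower number from compound 3 to compound 4 (0.01 log units; within the scatter), so a second methyl on this saturated chain carbon bound to the aromatic nitrogen left the number as unmoved as the first one did. Going by these compounds alone, the new comparison also spans both additions at once: isopropyl in place of methyl on the aromatic nitrogen gave a 1.8-fold higher number from compound 2 to compound 4 (0.26 log units; within the scatter), so even the two additions taken together stay within the scatter, which the single step from compound 2 to compound 3 could not show. Compound 4 gives a number rather than a limit, and compound 1 remains the only compound read as a limit: the limit of > 100000 nM in this assay, at which 1 of the 4 values shown sits.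

Methyl, ethyl and isopropyl are the only groups shown on this nitrogen, so it remains open whether a longer chain, a benzyl group or a chain ending in an amine or a carboxylic acid would produce a step beyond the scatter. The trifluoromethyl group and the two chlorine atoms also stay the same across compounds 2, 3 and 4, so these compounds say nothing about how replacing either of them, for instance the trifluoromethyl with a nitrile, would change the number.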